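The compounds below may be only part of what the source reports. "The series", "measured", "known", "first", "only" and "open" are said of these compounds alone.

Measured compounds:
compound 1 `CN(c1ncccc1CNc1nc(Nc2ccc3c(c2)CC(=O)N3)nc2[nH]cc(F)c12)S(C)(=O)=O` — 73200 nM
compound 2 `CN(c1ncccc1CNc1nc(Nc2ccccc2)nc2[nH]cc(F)c12)S(C)(=O)=O` — > 100000 nM
compound 3 `CC(=O)NCc1cccc(Nc2nc(NCc3cccnc3N(C)S(C)(=O)=O)c3c(F)c[nH]c3n2)c1` — 21700 nM

In a functional assay on SMMC-7721 cells (Homo sapiens) for inhibition, read by MTT assay, with a stated time of 48 h (a lower number here means a stronger inhibitor, a higher number a weaker inhibitor), compound 1 gives 73200 nM, the highest of the two numbers available. Compound 3 gives 21700 nM, so that a 3.4-fold lower number from compound 1 to compound 3 (0.53 log units; beyond the scatter). For compound 2 the result is only a limit of the assay, > 100000 nM; (the limit of > 100000 nM in this assay, at which 1 of the 3 values shown sits). Taken as a floor, an at least 1.3-fold higher number from compound 1 to compound 2 (0.13 log units; that floor lies within the scatter), and the gap from compound 2 to compound 3 appears as an at least 4.6-fold lower number from compound 2 to compound 3 (0.66 log units; beyond the scatter).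

Compound 4 `CC(=O)Nc1cccc(Nc2nc(NCc3cccnc3N(C)S(C)(=O)=O)c3c(F)c[nH]c3n2)c1` is not yet measured. It differs from compound 1 in that (a group of 10 heavy atoms (8 carbon, 1 nitrogen, 1 oxygen; one six-membered aromatic ring of carbon only) in place of a group of 10 heavy atoms (8 carbon, 1 nitrogen, 1 oxygen; one five-membered non-aromatic ring with 1 hetero atom, one six-membered aromatic ring of carbon only), on a nitrogen on an aromatic ring). Among the compounds with values here, two measured steps bear on this change: the step from compound 1 to compound 3 exchanges the same leaving group for a six-membered aromatic ring carrying an acetamide-bearing substituent and lowers the number modestly, while the step from compound 1 to compound 2, with the bare six-membered aromatic ring entering, moves the number at least a little upward to the limit. Compound 4 keeps the hydrogen-bond donor and acceptor that compound 2 lacks, so a change between no shift beyond the scatter and a modest lowering of the kind seen for compound 3 is expected, a 1.6-fold lower number from compound 1 to compound 4 (0.21 log units; within the scatter). For compound 4 the estimate is 45000 nM, with a range from 15000 nM to 110000 nM.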

Compound 4, half-maximal inhibitory concentration: 16000 nM
Compound 4: middle estimate off by 2.8-fold (0.45 log units), on the high side, within the range that was stated.
By their numbers in this assay, from the lowest: compounds 4 and 3 (each within the scatter of the next); then compound 1. At a limit, above all of these: compound 2.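

At this place, on a nitrogen on an aromatic ring, 3-acetamidophenyl in place of the group of compound 1 with the five-membered non-aromatic ring gives a 4.6-fold lower number from compound 1 to compound 4 (0.66 log units; beyond the scatter) in this assay, although the two groups match in their counts of heavy atoms, hydrogen-bond donors and acceptors. Acetamido in place of acetamidomethyl gives a 1.4-fold lower number from compound 3 to compound 4 (0.13 log units; within the scatter), so the two substituents cannot be told apart here. Compound 2 stands at a limit of the assay, so acetamido in place of hydrogen can be read only as a floor, an at least 6.2-fold lower number from compound 2 to compound 4 (0.79 log units; beyond the scatter): the limit of > 100000 nM in this assay, at which 1 of the 4 values shown sits.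

Still open, on these data alone, is whether the carbonyl or the amide hydrogen of the acetamido carries the step, which an amine or a carboxylic acid in its place would help to test. Also open, as far as these compounds go, is how a longer chain such as acetamidoethyl would read in this assay.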